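The compounds below may be only part of what the source reports. "The series", "measured", "known", "first", "only" and "open" are said of these compounds alone.

The study reports a small set of tetrazolyl acetamides and thioamides tested in an assay on HEK293 cells for activation of Kir3.1/Kir3.2 (Homo sapiens), read by thallium flux; on this read-out higher numbers stand for an effect only at larger amounts of compound and lower numbers for an effect already at smaller amounts. Compound 3, `Cc1cc(NC(=O)Cn2nnc(-c3ccc(F)cc3)n2)n(C2CCCCC2)n1`, gives 180 nM in this assay. Compound 1, `Cc1cc(NC(=S)Cn2nnc(-c3ccccc3)n2)n(C2CCCCC2)n1`, gives 623 nM, a higher number than that of compound 3, and the gap between the two lies beyond the usual scatter. Compound 2, `O=C(Cn1nnc(-c2ccccc2)n1)Nc1ccccn1`, is reported only as "not active" (no number reported) in this assay, without a number. Among the two compounds with a number, compound 3 thus stands lowest.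

Compound 4, `Cc1cc(NC(=O)Cn2nnc(-c3cccc(C#N)c3)n2)n(C2CCCCC2)n1`, has not yet been measured in this assay. It differs from compound 3 in one place: 3-cyanophenyl in place of 4-fluorophenyl on an aromatic carbon. Among the measured compounds shown here, no pair of measured compounds shows the effect of such a change, so the direction of the step can only be guessed. The author expects a small shift, if any, toward a higher number, with the step of a 1.7-fold higher number from compound 3 to compound 4 (0.22 log units; within the scatter) from compound 3 to compound 4 likely remaining within the scatter of this assay. Compound 4 is therefore estimated at 300 nM, with a range from 100 nM to 900 nM.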

Compound 4, half-maximal effective concentration: 183 nM
Compound 4: middle estimate off by 1.6-fold (0.21 log units), on the high side; low and high end bracket the measured number.
By their numbers in this assay, from the lowest: compounds 3 and 4 (each within the scatter of the next); then compound 1.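

In this assay, 3-cyanophenyl in place of 4-fluorophenyl gives a 1.0-fold higher number from compound 3 to compound 4 (0.01 log units; within the scatter), the first step seen at this aromatic carbon of the five-membered ring with 4 nitrogen. The position thus takes a group with a triple bond and a hydrogen-bond acceptor, neither of which 4-fluorophenyl has, and compound 3 and compound 4 cannot be told apart on this read-out. Nothing available explains this result.

The step replaces the fluorine with a nitrile and also alters where the substituent sits on the phenyl ring, so the compounds shown do not separate these two differences. They also leave open how this assay would read for a phenyl ring carrying an amine or a carboxylic acid, or for a longer alkyl chain in place of the ring.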